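Benzyl ring substitution in a weakly antiproliferative series

The compounds below may be only part of what the source reports. "The series", "measured", "known", "first", "only" and "open" are said of these compounds alone.

Among the measured compounds shown here, compound 1 `c1ccc(CSc2nnc(-c3ccc4c(c3)OCCO4)n2-c2ccccc2)cc1` holds the lower of the two numbers so far recorded in a functional assay on HeLa cells (Homo sapiens) for antiproliferative activity, read by MTT assay, with a stated time of 24 h; a higher number here means a weaker inhibitor, a lower number a stronger inhibitor; in this assay compound 1 gives 32800 nM. Compound 2 `O=[N+]([O-])c1cccc(CSc2nnc(-c3ccc4c(c3)OCCO4)n2-c2ccccc2)c1` carries nitro in place of hydrogen on an aromatic carbon, and in this assay compound 2 gives 45200 nM; the step of a 1.4-fold higher number from compound 1 to compound 2 (0.14 log units; within the scatter) is within the scatter. Compound 3 `Cc1ccccc1CSc1nnc(-c2ccc3c(c2)OCCO3)n1-c1ccccc1` has not yet been measured. It differs from compound 1 in one place: methyl in place of hydrogen on an aromatic carbon. For the measured compounds named here, the only measured step on the same ring is a 1.4-fold higher number from compound 1 to compound 2 (0.14 log units; within the scatter), and it barely moved the number. Going by the values given here, no step with methyl in place of hydrogen exists among the measured compounds, so the expectation for compound 3 rests on that single small step. In this assay the expected step is a 1.1-fold lower number from compound 1 to compound 3 (0.04 log units; within the scatter), that is, none beyond the scatter. For compound 3 the estimated value is 30000 nM, with a range from 12000 nM to 75000 nM.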

Compound 3, half-maximal inhibitory concentration: 36000 nM
The estimate for compound 3 lay 1.2-fold (0.08 log units) below the measured number; low and high end bracket the measured number.
By their numbers in this assay, from the lowest: compounds 1, 3 and 2 (each within the scatter of the next).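

With a 1.1-fold higher number from compound 1 to compound 3 (0.04 log units; within the scatter) in this assay, the change to 2-methylbenzyl shows that methyl ortho to a large group, a place on the ring that compound 2 does not touch, leaves the number within the scatter of the unsubstituted benzyl. The exchange of groups on this ring, a 1.3-fold lower number from compound 2 to compound 3 (0.10 log units; within the scatter) in this assay, also stays within the scatter, so the benzyl ring has so far tolerated all three forms without a readable change. No measurement available here bears on why these numbers stay together.

Still open, as far as these compounds go, is whether any substituent on this ring can move the number beyond the scatter, for example an amine or a carboxylic acid. Also open, from the compounds shown here alone, is whether a longer chain in place of the benzyl group, or a change elsewhere on the shared core, would do so.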